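Compound 2 to compound 4: 4-fluorobenzyl to 2-fluorobenzyl

A few compounds are considered here, and "the series" means these few. Any claim that something is new, unique, unknown or untested is made for them only; others in the source may bear on it.

Values in an ADME assay on HEK293 cells (Homo sapiens) for cytotoxicity, read by MTT assay, with a stated time of 24 h; a higher number here means a weaker inhibitor, a lower number a stronger inhibitor
compound 1 `COc1ccc(/C=C2\CN(C(=S)SCc3cn(Cc4ccccc4F)nn3)C/C(=C\c3ccc(OC)cc3)C2=O)cc1` gives "not determined" (no result reported)
compound 2 `Cc1ccc(/C=C2\CN(Cc3cn(Cc4ccc(F)cc4)nn3)C/C(=C\c3ccc(C)cc3)C2=O)cc1` gives "not determined" (no result reported)
compound 3 `O=C1/C(=C/c2ccccc2F)CN(C(=S)SCc2cn(Cc3ccc(F)cc3)nn2)C/C1=C\c1ccccc1F` gives 51300 nM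

Compound 2 has no single number in this assay, so it gives no direct starting point. Compound 4 `Cc1ccc(/C=C2\CN(Cc3cn(Cc4ccccc4F)nn3)C/C(=C\c3ccc(C)cc3)C2=O)cc1` differs from compound 2 in one place (2-fluorophenyl in place of 4-fluorophenyl on a saturated chain carbon bound to an aromatic nitrogen), with 2-fluorophenyl in place of 4-fluorophenyl on a saturated chain carbon bound to an aromatic nitrogen. Among the compounds with values here, no measured pair shows this change, so no step beyond the usual scatter is expected in this assay, in either direction. Within the data shown here, the only number comes from compound 3 (51300 nM), which differs from compound 4 in more than one place, so the range stays wide. Compound 4 is expected at about 45000 nM (estimated range 15000 nM to 100000 nM).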

Compound 4, half-maximal inhibitory concentration: > 100000 nM
Compound 4: no number, only a limit; the forecaster's own chance of this, stated with the estimate: 15%; middle value at least 2.2-fold (0.34 log units) away from the limit.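

In this assay compound 4 gives > 100000 nM, a limit and not a number. Compound 2 has no single number, so no step can be read between compound 2 and compound 4. The compounds shown leave open whether 2-fluorobenzyl in place of 4-fluorobenzyl changes the result in this assay.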